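Isopropyl for Methyl on a Shared Amide Core

A few compounds are considered here, and "the series" means these few. Any claim that something is new, unique, unknown or untested is made for them only; others in the source may bear on it.

Of the compounds shown here, three of one series have been tested in a functional assay on K562 cells (Homo sapiens) for cytotoxicity, with a stated time of 72 h; a higher number here means a weaker inhibitor, a lower number a stronger inhibitor. Compound 1 `CC(C)[C@H](NC(=O)c1cc(Cl)ccc1O)C(=O)Nc1ccc(Cl)cc1` gives > 20000 nM, which is a limit of the assay and not a number. Compound 2 `CC(C)[C@H](NC(=O)c1ccc(Cl)cc1O)C(=O)Nc1ccc(Br)cc1` gives > 10000 nM, again a limit. Compound 3 `C[C@H](NC(=O)c1ccc(Cl)cc1O)C(=O)Nc1ccc(Cl)cc1` gives > 10000 nM, also a limit. Within the data shown here, compound 3 thus stands at the edge of what this assay reports, as do the other two, as the limit of > 10000 nM in this assay, at which 2 of the 3 values shown sit, and the limit of > 20000 nM in this assay, at which 1 of the 3 values shown sits, show; no step between measured compounds can be sized from these values. Compound 4 `CC(C)[C@H](NC(=O)c1ccc(Cl)cc1O)C(=O)Nc1ccc(Cl)cc1` is not yet measured. It differs from compound 3 by isopropyl in place of methyl on a saturated chain carbon bound to an amide-type nitrogen and a carbonyl carbon. Among the measured compounds shown here, with every value so far a limit, no step in this assay can be read out of the series, and for this change none beyond the scatter is expected. Compound 4 is therefore estimated at 20000 nM in this assay, within 8000 nM to 50000 nM, most likely reported once more as a limit. The change itself is expected to amount to a step that the limit leaves unreadable from compound 3 to compound 4.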

Compound 4, half-maximal inhibitory concentration: > 10000 nM
Compound 4 gave a limit, no number; the forecaster's own chance of this, stated with the estimate: 85%; the middle value lies beyond the limit too.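

In this assay, among these compounds, compound 4 gives a limit and not a number, as do compound 1, compound 2 and compound 3, so no step from any of these three to compound 4 can be read. The compounds shown leave open how far any of these changes moves the cytotoxicity, since none yields a measurable value.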